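From isopropoxy to cyclobutyloxy on a shared core

The source may report more compounds than this note shows. Statements on the series, on what has been measured and on what is new or still open speak of the compounds shown alone.

Of the compounds shown here, three have been measured in a functional assay on HeLa cells (Homo sapiens) for antiproliferative activity, read by MTT assay, with a stated time of 48 h (a lower number here means a stronger inhibitor, a higher number a weaker inhibitor), so far.

- compound 1 (`COc1ccc(/C=C/C=C\c2cc(OC)c(OC)c(OC)c2)cc1O`) gives 62 nM
- compound 2 (`CCOc1cc(-c2ccc3cc[nH]c3c2)cn2c(-c3cc(OC)c(OC)c(OC)c3)nnc12`) gives 272 nM
- compound 3 (`COc1cc(-c2nnc3c(OC(C)C)cc(-c4ccc5[nH]ccc5c4)cn23)cc(OC)c1OC`) gives 261 nM

Compound 3 stands level with compound 2, since their two values lie within the usual scatter of each other. Compound 1 has the lower number, and its gap to compound 3 is beyond the scatter, so compound 3 is the weaker inhibitor of that pair.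

Compound 4 (`COc1cc(-c2nnc3c(OC4CCC4)cc(-c4ccc5[nH]ccc5c4)cn23)cc(OC)c1OC`) has not yet been measured. It carries cyclobutyl in place of isopropyl on an oxygen on an aromatic ring, and the rest of compound 3 stays unchanged.

Among the compounds with values here, no two measured compounds differ in one place only, so the data give no direct measure of such a swap. Compound 2 and compound 3 differ in more than one place, yet their values stay within the scatter of each other. A small change with no firm direction is therefore expected in this assay here. The estimated step runs a 1.1-fold higher number from compound 3 to compound 4 (0.06 log units; within the scatter) and is expected to stay within the scatter. The estimate for compound 4 is 300 nM with an expected range from 120 nM to 750 nM.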

Compound 4, half-maximal inhibitory concentration: 142 nM
For compound 4 the middle estimate is 2.1-fold (0.32 log units) above the measured one; the range from low to high includes it.
By their numbers in this assay, from the lowest: compound 1; then compounds 4, 3 and 2 (each within the scatter of the next).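

Within the data shown here, this is the first pair on the shared core that differs in one place only, so it gives the first direct reading of a swap at this position in this assay: replacing isopropyl with cyclobutyl gives a 1.8-fold lower number from compound 3 to compound 4 (0.26 log units; within the scatter). The swap adds one carbon and brings in a four-membered non-aromatic ring of carbon only, yet the step stays within the scatter of repeated measurements, so this pair shows no firm gain or loss from isopropoxy to cyclobutyloxy at this place on an oxygen on an aromatic ring. Nothing available explains this reading or bears on it.

A single pair cannot show how much variation this position accepts, and only carbon groups on this oxygen can be compared here, so an amine or a carboxylic acid at the end of the group, or a longer chain, could behave quite differently. From the compounds shown here alone, it also remains open whether a larger ring such as cyclopentyl or cyclohexyl would stay within the scatter of compound 3 or move clearly away from it.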